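The compounds below may be only part of what the source reports. "The series", "measured", "known", "first", "only" and "open" are said of these compounds alone.

Working notes on the series, read in a functional assay on A-375 cells (Homo sapiens) for activation, with a stated time of 3 days; on this read-out lower numbers stand for an effect already at smaller amounts and higher numbers for an effect only at larger amounts of compound. Compound 1 (`O=C(Nc1ccc(-c2cscn2)cc1)C1CN(Cc2ccc(F)c(F)c2)C1`) reports only a limit, > 20000 nM. Compound 2 (`O=C(Nc1ccc(-c2cscn2)cc1)C1CCCN(S(=O)(=O)c2ccc(F)c(F)c2)C1`) also reports only a limit, > 20000 nM. For the measured compounds named here, compound 3 (`O=C(Nc1ccc(-c2ccccc2)cc1)C1CCCN(Cc2ccc(F)c(F)c2)C1`) gives 5000 nM, the only actual number so far, and so the only reference point for the next compound.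

Compound 4 (`O=C(Nc1ccc(-c2cccnc2)cc1)C1CCCN(Cc2ccc(F)c(F)c2)C1`) has pyridin-3-yl in place of phenyl on an aromatic carbon, para to a large group: pyridin-3-yl in place of phenyl on an aromatic carbon.

Going by the values given here, no measured pair isolates this change, so its size cannot be read from the data. The expectation starts from compound 3 at 5000 nM and assumes a small shift in this assay, towards larger amounts of compound, at or only slightly beyond the usual scatter. The expected change is a 1.6-fold higher number from compound 3 to compound 4 (0.20 log units; within the scatter). A result reported only as a limit remains possible. For compound 4 the estimated value is 8000 nM, with an expected range of 3000 nM to 20000 nM.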

Compound 4, half-maximal effective concentration: 1060 nM
Estimate against measurement, compound 4: 7.5-fold (0.88 log units) above; measured number outside the range, below it.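

In this assay, pyridin-3-yl in place of phenyl on an aromatic carbon, para to a large group, gives a 4.7-fold lower number from compound 3 to compound 4 (0.67 log units; beyond the scatter). For the compounds shown here, this is the first step that can be read, and it shows that the read-out responds to the ring at this position, with the step beyond the usual scatter and towards an effect at smaller amounts of compound. Only this one step carries a size, and no other step can be read from the series: the limit of > 20000 nM in this assay, at which 2 of the 4 values shown sit.

Going by these compounds, how pyridin-4-yl or pyrimidin-5-yl would compare on this aromatic carbon remains open, so the ring nitrogen of compound 4 cannot yet be tied to this position in the ring. On these data alone, whether the same change holds on the cores of compound 1 and compound 2 also remains open.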